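Replacing the oxanyl on the ring nitrogen with cyclohexylcarbonyl

The source may hold more compounds than are shown below. What is called first, only, known or untested is meant among the compounds shown, and "the series" means these compounds.

For the measured compounds named here, compound 2 `CC(C)(C)c1cc(NC(=O)[C@@H]2CCCCN2C2CCOCC2)no1` gives 74 ug/mL in a physicochemical assay for solubility, read by HPLC, at pH 6.8 (a higher number here means a more soluble compound, a lower number a less soluble compound), and compound 1 `CC(C)(C)c1cc(NC(=O)[C@@H]2CCCCN2C2CC2)no1` gives 38 ug/mL; the only step measured so far, a 1.9-fold higher number from compound 1 to compound 2 (0.29 log units; within the scatter), changes the group on that ring nitrogen. Compound 3 `CC(C)(C)c1cc(NC(=O)[C@@H]2CCCCN2C(=O)C2CCCCC2)no1` differs from compound 2 by cyclohexylcarbonyl in place of oxan-4-yl on an amine nitrogen in a ring. Going by the values given here, that measured step is the only one bearing on this change, and it stayed within the scatter, so no step beyond the scatter is firmly indicated in this assay, although the entering group is the larger one. Compound 3 is estimated at 30 ug/mL, with a range from 10 ug/mL to 90 ug/mL. This estimate means a step of a 2.5-fold lower number from compound 2 to compound 3 (0.39 log units; beyond the scatter).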

Compound 3, solubility: 6.4 ug/mL
Compound 3: middle estimate off by 4.7-fold (0.67 log units), on the high side; the whole stated range lies above it.
By their numbers in this assay, from the lowest: compound 3; then compounds 1 and 2 (each within the scatter of the next).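

At this position, in this assay cyclohexylcarbonyl stands clearly apart from both earlier groups, with a 12-fold lower number from compound 2 to compound 3 (1.06 log units; beyond the scatter) and a 5.9-fold lower number from compound 1 to compound 3 (0.77 log units; beyond the scatter) as its steps. For the compounds shown here, the earlier exchange of cyclopropyl for oxan-4-yl stayed within the scatter, so this is the first change on the ring nitrogen that separates compounds. No measurement shown gives a reason for the drop.

Cyclohexylcarbonyl brings a carbonyl and a carbon-only ring together, so the compounds shown leave open which of the two goes with the step. A plain cyclohexyl or an acetyl on the same nitrogen would pull them apart.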